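The source may hold more compounds than are shown below. What is called first, only, known or untested is meant among the compounds shown, and "the series" means these compounds.

Compound 1 `COc1cc(N2C(N)=C(C#N)C(c3ccc([N+](=O)[O-])cc3)C3=C2CC(C)(C)CC3=O)cc(OC)c1OC` is one of three compounds with numbers in a functional assay on Ehrlich cells (Mus musculus) for cytotoxicity, tested at 10 ug/mL; a lower number here means a weaker effect, a higher number a stronger effect of the compound at the concentration tested. In this assay compound 1 gives 10%, compound 2 `COc1cc(N2C(N)=C(C#N)C(/C=C/c3ccccc3)C3=C2CC(C)(C)CC3=O)cc(OC)c1OC` gives 10%, and compound 3 `COc1cc(N2C(N)=C(C#N)C(c3c(OC)ccc4ccccc34)C3=C2CC(C)(C)CC3=O)cc(OC)c1OC` gives 0%. Compound 1 thus stands level with compound 2, the two together at the top of the three numbers, while the step to compound 3 was a number 10 percentage points lower from compound 1 to compound 3 (within the scatter). Compound 4 `COc1cc(N2C(N)=C(C#N)C(c3ccc(OC)c4ccccc34)C3=C2CC(C)(C)CC3=O)cc(OC)c1OC` has not yet been measured in this assay. It differs from compound 1 in one place: 4-methoxynaphthalen-1-yl in place of 4-nitrophenyl on a saturated ring carbon. The measured steps that bear on this change are those that replace the same aryl group on the same saturated ring carbon: a number 10 percentage points lower from compound 1 to compound 3 (within the scatter) and a number 10 percentage points lower from compound 2 to compound 3 (within the scatter), both with a naphthyl group entering. Neither step went beyond the scatter, so no step beyond the scatter is expected from compound 1 to compound 4 either, and the estimated step of a number 5 percentage points lower from compound 1 to compound 4 (within the scatter) reflects this. For compound 4 the expected value in this assay is 5%, with a range from 0% to 20%.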

Compound 4, a percentage reported as activity, at one concentration (the size of the read-out at that concentration, not a potency): 10%
For compound 4 the middle estimate is 5 percentage points below the measured one, within the range that was stated.
By their numbers in this assay, from the lowest: compounds 3, 1, 2 and 4 (each within the scatter of the next).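

In this assay, 4-methoxynaphthalen-1-yl in place of 4-nitrophenyl on the saturated ring carbon gave no change at the digits printed from compound 1 to compound 4 (within the scatter) and in place of 2-phenylethenyl gave no change at the digits printed from compound 2 to compound 4 (within the scatter) at this same carbon. The two methoxynaphthalenyl groups can now also be compared directly: 4-methoxynaphthalen-1-yl in place of 2-methoxynaphthalen-1-yl gave a number 10 percentage points higher from compound 3 to compound 4 (within the scatter), so among these four compounds neither the aryl group nor the place of the methoxy group on the naphthalene moves the read-out beyond the scatter. Nothing available accounts for these numbers.

The compounds shown leave open whether a longer alkyl chain, a carboxylic acid or an amine on this carbon would produce a step beyond the scatter. They also leave open how these compounds behave at other concentrations.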